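Adding a second methyl to an aryl imidazolylmethyl imidazolidinone

The source may report more compounds than this note shows. Statements on the series, on what has been measured and on what is new or still open speak of the compounds shown alone.

The study concerns antagonists of the receptor measured in a functional assay (Cavia porcellus) for antagonist activity at Serotonin 3 (5-HT3) receptor (Homo sapiens); on this read-out higher numbers stand for weaker inhibition and lower numbers for stronger inhibition. Compound 2 `O=C1N(c2ccccc2)CCN1C1CN2CCC1CC2` gives 2100 nM. Compound 1 `Cc1cccc(N2CCN(C3CN4CCC3CC4)C2=O)c1` gives 12 nM, and the step of a 180-fold lower number from compound 2 to compound 1 (2.24 log units; beyond the scatter) is methyl in place of hydrogen on an aromatic carbon. Compound 3 `Cc1cccc(N2CCN(Cc3nc[nH]c3C)C2=O)c1` gives 45.7 nM, a number higher than that of compound 1 and far lower than that of compound 2; the difference between the cores of compound 3 and compound 2 is not broken down here.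

Compound 4 `Cc1cc(C)cc(N2CCN(Cc3nc[nH]c3C)C2=O)c1` has not yet been measured. It differs from compound 3 by methyl in place of hydrogen on an aromatic carbon. This is the same kind of change as that from compound 2 to compound 1, but the place differs: in compound 4 the entering methyl sits meta to a methyl group as well as meta to a large group, whereas in compound 1 it sits only meta to a large group.

Because the step of a 180-fold lower number from compound 2 to compound 1 (2.24 log units; beyond the scatter) was large, a lower number for compound 4 is expected, though a smaller step, since the first methyl is already present in compound 3. The estimated step is a 2.3-fold lower number from compound 3 to compound 4 (0.36 log units; beyond the scatter). For compound 4 a value of 20 nM is expected, between 5 nM and 80 nM.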

Compound 4, antagonist equilibrium constant: 50.1 nM
For compound 4 the middle estimate is 2.5-fold (0.40 log units) below the measured one, within the range that was stated.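

In this assay the second methyl leaves compound 3 and compound 4 indistinguishable, with a 1.1-fold higher number from compound 3 to compound 4 (0.04 log units; within the scatter). Methyl in place of hydrogen on an aromatic carbon therefore does not carry over as a fixed gain from the core of compound 2 to the core of compound 3: the same change on two cores in this assay, a 180-fold lower number (2.24 log units; beyond the scatter) from compound 2 to compound 1 and a 1.1-fold higher number (0.04 log units; within the scatter) from compound 3 to compound 4, 190-fold (2.28 log units) apart, beyond the scatter of two such steps This does not show which difference is responsible, since the entering methyl of compound 4 sits meta to a methyl group as well as meta to a large group, and the pairs shown do not separate that difference of place from the difference between the cores.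

Open, as far as these compounds go, is how the core of compound 3 would respond to the first methyl, which would need its counterpart with hydrogen in place of the methyl on the six-membered ring. Also open, from the compounds shown here alone, is whether a chlorine atom or a methoxy group in place of the entering methyl would follow the same course on either core.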